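A Methoxy Swap in a Weakly Cytotoxic Series

This account rests on a few compounds, and the source may have more. Where it says the series, first, only, none or still open, it means among the compounds named here.

Measured in a functional assay on MCF7 cells (Homo sapiens) for cytotoxicity, read by MTT assay, with a stated time of 48 h; on this read-out lower numbers stand for stronger inhibition and higher numbers for weaker inhibition:
- compound 1 `COc1cc(-c2nnc3n2NC(c2ccco2)C(C(=O)c2ccc(F)cc2)S3)cc(OC)c1OC`: > 100000 nM, a limit of the assay rather than a number
- compound 2 `COc1cc(-c2nnc3n2NC(c2ccco2)C(C(=O)c2ccc(O)cc2)S3)cc(OC)c1OC`: 88900 nM
- compound 3 `COc1cc(-c2nnc3n2NC(c2ccco2)C(C(=O)c2cccc(Br)c2)S3)cc(OC)c1OC`: 91800 nM

Compound 3 holds the highest of the two actual numbers, and compound 2 is its nearest neighbour: a 1.0-fold higher number from compound 2 to compound 3 (0.01 log units; within the scatter). For compound 1 only the limit of > 100000 nM in this assay, at which 1 of the 3 values shown sits, is known. Every change so far has touched the aryl group on the carbonyl, and none has moved the read-out beyond the scatter: an at least 1.1-fold lower number from compound 1 to compound 2 (0.05 log units; that floor lies within the scatter) and an at least 1.0-fold lower number from compound 1 to compound 3 (0.03 log units; that floor lies within the scatter) are both floors only.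

Compound 4 `COc1cccc(C(=O)C2Sc3nnc(-c4cc(OC)c(OC)c(OC)c4)n3NC2c2ccco2)c1` is the next step: methoxy in place of bromo on an aromatic carbon. The closest guide is the step from a hydroxyphenyl to a bromophenyl, a 1.0-fold higher number from compound 2 to compound 3 (0.01 log units; within the scatter), which changed nothing beyond the scatter, and the step from compound 1, which sits at a limit. Among the measured compounds shown here, no step is therefore expected beyond the scatter, a 1.0-fold higher number from compound 3 to compound 4 (0.00 log units; within the scatter). Compound 4 is estimated at 92000 nM, within a range from 45000 nM to 200000 nM, with a real chance that only a limit is reported.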

Compound 4, half-maximal inhibitory concentration: > 100000 nM
Compound 4: only a limit was reported; the forecaster's own chance of this, stated with the estimate: 35%; at least 1.0-fold (0.03 log units) between middle value and limit.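

Putting methoxy where compound 3 carries bromo, turning 3-bromophenyl into 3-methoxyphenyl, brings no stronger inhibition at this position: an at least 1.0-fold higher number from compound 3 to compound 4 (0.03 log units; that floor lies within the scatter). On these data alone, the comparison with the hydroxy-bearing compound reads the same way, an at least 1.1-fold higher number from compound 2 to compound 4 (0.05 log units; that floor lies within the scatter), and both figures are only floors, so the true size of each step remains unknown. The step between compound 1 and compound 4 cannot be read, and limits now cover much of this small series: the limit of > 100000 nM in this assay, at which 2 of the 4 values shown sit.

As far as these compounds go, it remains open whether an amine or a carboxylic acid in place of the methoxy in the 3-methoxyphenyl group would move the read-out beyond the scatter. From the compounds shown here alone, the shared core is the same in all four compounds, so the effect of a change there also remains open.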